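From compound 2 to a carbamoyl compound

The compounds below may be only part of what the source reports. "The series", "measured", "known", "first", "only" and "open" are said of these compounds alone.

In a functional assay on HCT-116 cells (Homo sapiens) for inhibition, read by luminescence and CellTiter-Glo, with a stated time of 72 h (on this read-out lower numbers stand for stronger inhibition and higher numbers for weaker inhibition), compound 1 (`C/C=C/C(=O)Nc1cccc2c1cc(C)n2-c1nc2c(c(NCc3cccc(O)c3)n1)CCC2`) gives 2400 nM and compound 2 (`Cc1cc2c(NC(=O)c3ccco3)cccc2n1-c1nc2c(c(NCc3cccc(O)c3)n1)CCC2`) gives 1200 nM. Compound 2 therefore stands within the scatter of compound 1. Compound 3 (`Cc1cc2c(C(N)=O)cccc2n1-c1nc2c(c(NCc3cccc(O)c3)n1)CCC2`) has carbamoyl in place of ((furan-2-yl)carbonyl)amino on an aromatic carbon. Going by the values given here, the only measured step (a 2.0-fold lower number from compound 1 to compound 2 (0.30 log units; within the scatter)) lies within the scatter and changed only the group on a carbonyl carbon, so it offers no direction. No change beyond the scatter is expected, and the estimated 1.3-fold higher number from compound 2 to compound 3 (0.10 log units; within the scatter) has no firm direction. Compound 3 is estimated at 1500 nM (400 nM to 5000 nM).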

Compound 3, half-maximal inhibitory concentration: 400 nM
Estimate against measurement, compound 3: 3.8-fold (0.57 log units) above; low and high end bracket the measured number.
By their numbers in this assay, from the lowest: compound 3; then compounds 2 and 1 (each within the scatter of the next).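

In this assay, replacing the whole group on this aromatic carbon does more than the earlier change to what sits on the carbonyl carbon: carbamoyl gives a 3.0-fold lower number from compound 2 to compound 3 (0.48 log units; beyond the scatter) and a 6.0-fold lower number from compound 1 to compound 3 (0.78 log units; beyond the scatter). Both steps lie beyond the scatter, so at this position the smaller carbamoyl, with no ring, is accompanied by a lower number than either larger group. Nothing available explains this gain. Which part of carbamoyl matters stays open, and a carboxylic acid, a nitrile or a methylcarbamoyl group at this position could help separate those parts.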